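The source may hold more compounds than are shown below. What is called first, only, known or untested is meant among the compounds shown, and "the series" means these compounds.

Among the compounds with values here, in a functional assay on HeLa cells (Homo sapiens) for cytotoxicity, read by MTT assay, with a stated time of 48 h (a lower number here means a stronger inhibitor, a higher number a weaker inhibitor), compound 1 (`C[n+]1cccc(OP(=O)([O-])OC[C@H]2O[C@@H](n3cc(F)c(=O)[nH]c3=O)C[C@@H]2OC(=O)c2ccccc2)c1`) gives 1260 nM, the highest number among the three compounds measured so far. Compound 2 (`O=C(O[C@H]1C[C@H](n2cc(F)c(=O)[nH]c2=O)O[C@@H]1COP(=O)([O-])Oc1ccc[n+](Cc2ccccc2)c1)c1ccccc1`) gives 530 nM, and compound 3 (`CCOC(=O)C[n+]1cccc2cc(OP(=O)([O-])OC[C@H]3O[C@@H](n4cc(F)c(=O)[nH]c4=O)C[C@@H]3OC(=O)c3ccccc3)ccc21`) gives 600 nM. Compound 4 (`C[N+]1(C)CCC(OP(=O)([O-])OC[C@H]2O[C@@H](n3cc(F)c(=O)[nH]c3=O)C[C@@H]2OC(=O)c2ccccc2)CC1`) has yet to be measured. It departs from compound 1 in the group on an oxygen whose other neighbours are: phosphorus, and the change is a group of 8 heavy atoms (7 carbon, 1 nitrogen; one six-membered non-aromatic ring with 1 hetero atom) in place of a group of 7 heavy atoms (6 carbon, 1 nitrogen; one six-membered aromatic ring with 1 hetero atom), on an oxygen. Both groups carry a net charge of +1, but the aromatic ring gives way to a non-aromatic one.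

Within the data shown here, only one measured step bears on this, and only loosely: a 2.4-fold lower number from compound 1 to compound 2 (0.38 log units; beyond the scatter), with phenyl in place of hydrogen on a saturated chain carbon bound to an aromatic nitrogen. That step is modest and leaves the aromatic ring in place. Among the measured compounds shown here, no measured compound has a non-aromatic ring here, so the data do not show what this replacement does. A step of about the same size is expected, but tentatively, and in the opposite direction, towards a higher number. The expected step is a 2.2-fold higher number from compound 1 to compound 4 (0.35 log units; beyond the scatter). For compound 4 the estimated value is 2800 nM, with an expected range from 700 nM to 10000 nM.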

Compound 4, half-maximal inhibitory concentration: 27200 nM
Estimate against measurement, compound 4: 9.7-fold (0.99 log units) below, and the stated range ends below it.
By their numbers in this assay, from the lowest: compounds 2 and 3 (each within the scatter of the next); then compound 1; then compound 4.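

In this assay, within the data shown here, the group on an oxygen whose other neighbours are: phosphorus proves far more sensitive than the earlier compounds could show: a non-aromatic ring in place of the aromatic one, with the net charge of +1 unchanged, gives a 22-fold higher number from compound 1 to compound 4 (1.33 log units; beyond the scatter). That large step stands against the modest 2.4-fold lower number from compound 1 to compound 2 (0.38 log units; beyond the scatter), which left the aromatic ring in place, so among these compounds a net charge of +1 on a six-membered ring with 1 hetero atom does not by itself preserve the number seen for compound 1. The data shown offer no measurement that explains why this replacement costs so much.

The compounds shown leave open whether the loss follows the aromatic ring itself or some other difference between the two groups, and an open-chain trimethylammonium group or a plain phenyl group with no nitrogen on the same oxygen would help separate these possibilities. From the compounds shown here alone, it also remains open whether a benzyl group on the nitrogen of the non-aromatic ring would bring a step like the one seen on the aromatic ring.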